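Swapping the aryl for a small ring on the shared core

A few compounds are considered here, and "the series" means these few. Any claim that something is new, unique, unknown or untested is made for them only; others in the source may bear on it.

Compound 1 `O=C(C1CC1)N1CCN(Cc2nc3ccccc3n2Cc2cccc(F)c2)CC1` carries a cyclopropyl carbonyl on one end of the shared core and a 3-fluorobenzyl on the other. In an assay on isolated protein for inhibition of aldehyde dehydrogenase 1A1 (Homo sapiens), read by spectrophotometry, tested at 10 uM (a higher number here means more inhibition at the concentration tested (going by the name of the read-out), a lower number less inhibition), compound 1 gives 27.2%, the second highest of the three numbers. Compound 2 `Cc1cccc(Cn2c(CN3CCN(C(=O)CC(C)C)CC3)nc3ccccc32)c1` gives 71.4%, a number beyond the scatter above compound 1, while compound 3 `Cc1cccc(Cn2c(CN3CCN(C(=O)c4ccncc4)CC3)nc3ccccc32)c1` gives 20.6%, within the scatter of compound 1. Among the measured compounds shown here, the one measured step, a number 50.8 percentage points lower from compound 2 to compound 3 (beyond the scatter), concerns a replacement on the carbonyl carbon and is large.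

For the measured compounds named here, compound 4 `O=C(C1CC1)N1CCN(Cc2nc3ccccc3n2CC2CC2)CC1` differs from compound 1 by cyclopropyl in place of 3-fluorophenyl on a saturated chain carbon bound to an aromatic nitrogen, a change at a different place from the one probed by the step from compound 2 to compound 3. Going by the values given here, no measured step therefore bears directly on it, and the data give no basis for expecting a step beyond the scatter in either direction. Compound 4 is accordingly expected to give about 22% in this assay, somewhere between 5% and 45%, the estimated step being a number 5.2 percentage points lower from compound 1 to compound 4 (within the scatter).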

Compound 4, a percentage reported as inhibition, at one concentration (the size of the read-out at that concentration, not a potency): 21.2%
For compound 4 the middle estimate is 0.8 percentage points above the measured one; low and high end bracket the measured number.
By their numbers in this assay, from the lowest: compounds 3, 4 and 1 (each within the scatter of the next); then compound 2.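

Among the compounds shown here, the change from 3-fluorobenzyl to cyclopropylmethyl is the only step read at this position, on a saturated chain carbon bound to an aromatic nitrogen. In this assay it gives a number 6 percentage points lower from compound 1 to compound 4 (within the scatter), so here the number stays within the scatter when the six-membered aromatic ring and its fluorine give way to a three-membered non-aromatic ring. No evidence is available that would explain this result.

As far as these compounds go, it remains open whether cyclopropyl would read the same way on this chain carbon alongside the isobutyl carbonyl of compound 2, instead of the cyclopropyl carbonyl of compound 1. Also open, from the compounds shown here alone, is how an amine or a longer chain such as n-butyl would read on the same aromatic nitrogen.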